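The source may report more compounds than this note shows. Statements on the series, on what has been measured and on what is new or still open speak of the compounds shown alone.

Measured so far in a functional assay on HeLa cells (Homo sapiens) for inhibition, read by CCK-8 assay, with a stated time of 72 h, tested at 8 uM; on this read-out higher numbers stand for more inhibition of growth at the one concentration tested and lower numbers for less inhibition of growth:
- compound 1 `Cc1ccc(SCc2ccc(C(=O)Nc3ccccc3N)cc2)cc1` gives 79.2%
- compound 2 `Nc1ccccc1NC(=O)c1ccc(CSc2ccc(Br)cc2)cc1` gives 38.2%

Compound 2 holds the lower of the two numbers, and its gap to compound 1 lies beyond the scatter. The open case is compound 3 `Nc1ccccc1NC(=O)c1ccc(CSc2ccc(Cl)cc2)cc1`, not yet measured in this assay and separated from compound 2 by one change: chloro in place of bromo on an aromatic carbon, para to a large group.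

Within the data shown here, only one measured step bears on this place. It is a number 41 percentage points lower from compound 1 to compound 2 (beyond the scatter), with bromo in place of methyl on an aromatic carbon. Among the measured compounds shown here, no chloro compound has been measured, so this step gives only a rough outer scale and no direct reading of the exchange. A much smaller step than that one is expected here, probably within the scatter, with a slight upward lean. The step expected is a number 7.8 percentage points higher from compound 2 to compound 3 (within the scatter) as a working figure. Compound 3 is estimated at 46% with an expected range from 30% to 68% for a single measurement.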

Compound 3, percent growth inhibition at one concentration: 51.4%
Estimate against measurement, compound 3: 5.4 percentage points below, within the range that was stated.
By their numbers in this assay, from the lowest: compound 2; then compound 3; then compound 1.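

In this assay, exchanging one halogen for the other at this position is not a silent change: a number 13.2 percentage points higher from compound 2 to compound 3 (beyond the scatter), with chloro in place of bromo on the ring carbon para to a large group. The chloro compound still does not reach the methyl compound, as a number 27.8 percentage points lower from compound 1 to compound 3 (beyond the scatter) shows, so a third point now places the three groups in a clear order, with bromo lowest, chloro in the middle and methyl highest, and with both halogens short of methyl. Nothing available offers a reason for this order or for the size of either step.

Still open, from the compounds shown here alone, is how fluoro, methoxy, an amine or a longer chain such as ethyl would read at this same position, and whether any of them would match or pass methyl. All three numbers also come from a single tested concentration, so whether the same order would hold across a full concentration range remains unsettled.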